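The source may hold more compounds than are shown below. What is called first, only, known or untested is meant among the compounds shown, and "the series" means these compounds.

Measured compounds:
compound 1, `CCCSc1nc(Cl)c2c(n1)N(Cc1cccs1)C(C(=O)N1CCN(C)CC1)N2`, 5020 nM in a functional assay on PC-3 cells (Homo sapiens) for antiproliferative activity, read by MTT assay, with a stated time of 72 h; a lower number here means a stronger inhibitor, a higher number a weaker inhibitor
compound 2, `CCCSc1nc(Cl)c2c(n1)N(Cc1ccccc1)C(C(=O)N1CCN(C)CC1)N2`, 29800 nM
compound 3, `CCCSc1nc(Cl)c2c(n1)N(Cc1ccccc1)C(C(=O)OCC)N2`, 62500 nM

Compound 2 stands second highest of the three numbers in this assay; compound 3 sits nearest, and compound 1 furthest below. The unmeasured compound 4, `CCCSc1nc(Cl)c2c(n1)N(Cc1ccco1)C(C(=O)N1CCN(C)CC1)N2`, differs from compound 2 by furan-2-yl in place of phenyl on a saturated chain carbon bound to a nitrogen on an aromatic ring in a ring. Among the compounds with values here, of the measured steps, only the one between compound 1 and compound 2 touches the same place: a 5.9-fold higher number from compound 1 to compound 2 (0.77 log units; beyond the scatter). The step of a 2.1-fold higher number from compound 2 to compound 3 (0.32 log units; beyond the scatter) changes a different site and does not bear on compound 4. The thiophen-2-yl compound 1 gave the lower number, and furan-2-yl is likewise a five-membered aromatic ring with one hetero atom, so a lower number than compound 2 is expected for compound 4, though a smaller move than that of compound 1 is assumed, since oxygen for sulfur is not covered by any measured pair. The expected step is a 2.7-fold lower number from compound 2 to compound 4 (0.43 log units; beyond the scatter). Compound 4 is estimated at 11000 nM, within 4000 nM to 32000 nM.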

Compound 4, half-maximal inhibitory concentration: 11400 nM
Compound 4: middle estimate off by 1.0-fold (0.02 log units), on the low side, and the stated range covers the measured number.
By their numbers in this assay, from the lowest: compound 1; then compound 4; then compound 2; then compound 3.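

In this assay, furan-2-yl in place of phenyl also lowers the number (a 2.6-fold lower number from compound 2 to compound 4 (0.42 log units; beyond the scatter)), so the gain at this position is no longer tied to thiophen-2-yl alone. Compound 1 and compound 4 also show that the two five-membered rings are not interchangeable here (a 2.3-fold higher number from compound 1 to compound 4 (0.36 log units; beyond the scatter)): a change of the ring hetero atom, with the ring size kept, is enough to move the number beyond the scatter. No measurement at hand explains either step.

As far as these compounds go, whether a pyridyl ring or a saturated cyclohexyl group on the same chain carbon would continue this order remains open. Also open, from the compounds shown here alone, is whether furan-2-yl and thiophen-2-yl would lower the number with ethoxy on the carbonyl carbon, since compound 3 carries phenyl only.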